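Working notes: the step from compound 2 to compound 3

The source may report more compounds than this note shows. Statements on the series, on what has been measured and on what is new or still open speak of the compounds shown alone.

Measured so far in an assay on mitochondria from brain for inhibition of Amine oxidase [flavin-containing] B (Bos taurus); a lower number here means a stronger inhibitor, a higher number a weaker inhibitor:
- compound 1 `CN(Cc1ccccc1)C(=O)c1ccc[nH]1`: 300000 nM
- compound 2 `CN(Cc1ccccc1)C(=O)c1cccn1C`: 300000 nM

Among the compounds with values here, compound 2 stands level with compound 1 at the digits printed; the only measured step, no change at the digits printed from compound 1 to compound 2 (within the scatter), is within the scatter. Both inhibition constants lie far up the scale, so the series as measured is weak in this assay.

Compound 3 `CN(Cc1ccccc1F)C(=O)c1cccn1C` has not yet been measured. Within the data shown here, it differs from compound 2 by fluoro in place of hydrogen on an aromatic carbon, on the part of the molecule that the one measured step did not touch. Among the measured compounds shown here, that step, no change at the digits printed from compound 1 to compound 2 (within the scatter), gives no sign of a sensitive point in the structure, and no step bears directly on a change on the six-membered aromatic ring of carbon only. The expectation is therefore no step beyond the scatter in this assay.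

For compound 3 the estimated inhibition constant in this assay is 300000 nM, with a range from 100000 nM to 900000 nM. The step this estimate means for compound 3 is no change at the digits printed from compound 2 to compound 3 (within the scatter), expected to lie within the scatter.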

Compound 3, inhibition constant: 140000 nM
Compound 3: the middle estimate sits 2.1-fold (0.33 log units) above what was measured; the measured number falls inside the stated range.
By their numbers in this assay, from the lowest: compound 3; then compounds 1 and 2 (each within the scatter of the next).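

In this assay, within the data shown here, fluoro in place of hydrogen on an aromatic carbon of the six-membered aromatic ring of carbon only, ortho to a large group, gives a 2.1-fold lower number from compound 2 to compound 3 (0.33 log units; beyond the scatter), the first step to lie beyond the scatter. Among these compounds, this ring therefore responds to a change of a single heavy atom, whereas the one earlier change, methyl in place of hydrogen on an aromatic nitrogen, gave no change at the digits printed from compound 1 to compound 2 (within the scatter), and the new step is modest, with compound 3 still far up the scale at 140000 nM. No measurement at hand bears on the reason for this step, so the result stands as an observation only.

The compounds shown leave open whether a chloro group, a methoxy group or an amine in the same place would carry the number further down or reverse the step, and whether a single fluoro group elsewhere on this ring would act in the same way. They also leave open whether the fluoro step holds with the hydrogen of compound 1 on the aromatic nitrogen in place of the methyl group.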